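The compounds below may be only part of what the source reports. "The series", "measured", "known", "first", "only" and "open" are said of these compounds alone.

Compound 1 `O=C1C=CC(OCC(F)(F)F)N1c1ccc(C(F)(F)F)cc1`: 2300 nM
Compound 2 `O=C1C=CC(OC(C(F)(F)F)C(F)(F)F)N1c1ccc(Cl)cc1`: 2410 nM

Of the compounds shown here, two have been measured in a functional assay on MDA-MB-231 cells (Homo sapiens) for inhibition; on this read-out higher numbers stand for weaker inhibition and lower numbers for stronger inhibition. Compound 1 gives 2300 nM in this assay, and compound 2 gives 2410 nM. These two numbers lie within the usual scatter of each other, so they cannot be told apart, and compound 1 and compound 2 differ in more than one place, so no single step can be read from them.

Compound 3 `O=C1C=CC(OCC(F)(F)F)N1c1ccc(Br)cc1` is the next compound, not yet measured. It differs from compound 1 in one place: bromo in place of trifluoromethyl on an aromatic carbon. For the measured compounds named here, no measured pair shows what this change does here, so the expectation rests only on the number for compound 1. Compound 3 is expected to give roughly 2500 nM in this assay, with a range from 1000 nM to 6500 nM. This amounts to an expected step of a 1.1-fold higher number from compound 1 to compound 3 (0.04 log units; within the scatter), which is not expected to go beyond the scatter in either direction.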

Compound 3, half-maximal inhibitory concentration: 7570 nM
Beside the measured number, compound 3's estimate is 3.0-fold (0.48 log units) below it, and the stated range ends below it.
By their numbers in this assay, from the lowest: compounds 1 and 2 (each within the scatter of the next); then compound 3.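

For the compounds shown here, this is the first single change that can be read in this assay: bromo in place of trifluoromethyl on an aromatic carbon gives a 3.3-fold higher number from compound 1 to compound 3 (0.52 log units; beyond the scatter), a modest loss of inhibition. It shows that this position is sensitive to which group it carries, at least for these two groups on the core of compound 1. Going by these compounds alone, nothing measured so far points to a cause for this step.

Within the data shown here, one pair cannot show how far this sensitivity extends, and compound 2, which carries chloro, differs from compound 1 and compound 3 in more than one place, so no step to it can be read. Also open, from the compounds shown here alone, is how a smaller group such as fluoro, or an amine or a carboxylic acid, would behave on this same aromatic carbon.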